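A Furan-2-yl Analogue and Its Expected Cytotoxicity

A few compounds are considered here, and "the series" means these few. Any claim that something is new, unique, unknown or untested is made for them only; others in the source may bear on it.

Compound 2 `CCOC(=O)CCCCCOc1cccc(CN(C(=O)c2ccc(-c3ccncc3)cc2)C(C)C)c1` has been examined in an ADME assay on HepG2 cells (Homo sapiens) for cytotoxicity, read by CellTiter-Glo and resazurin assay, with a stated time of 72 h; on this read-out lower numbers stand for an effect already at smaller amounts and higher numbers for an effect only at larger amounts of compound. In this assay compound 2 reached only the assay limit of > 26000 nM, a limit rather than a measured number. Compound 1 `CC(C)N(Cc1cccc(OCCCCCC(=O)O)c1)C(=O)c1ccc(-c2ccco2)cc1` also carries a furan-2-yl ring, and in this assay compound 1 likewise sits at the limit of > 26000 nM. Both values shown thus share (the limit of > 26000 nM in this assay, at which 2 of the 2 values shown sit), so no direction of change has been observed within this set. Compound 3 `CCOC(=O)CCCCCOc1cccc(CN(C(=O)c2ccc(-c3ccco3)cc2)C(C)C)c1` is yet to be measured in this assay. Compared with compound 2 it differs in one place: furan-2-yl in place of pyridin-4-yl on an aromatic carbon. The step from compound 2 to compound 3 is expected to be none beyond the scatter, a step that the limit leaves unreadable from compound 2 to compound 3, because compound 1 with its furan-2-yl already gives > 26000 nM in this assay. Compound 3 is therefore estimated at 30000 nM, within a range from 13000 nM to 100000 nM, and most likely reported again only as a limit.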

Compound 3, half-maximal effective concentration: > 26000 nM
Compound 3 ended at the assay's limit; the forecaster's own chance of this, stated with the estimate: 85%; the middle value lies beyond the limit too.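

In this assay no step can be read between compound 3 and either compound 2 or compound 1, as all three values are limits and not numbers: the limit of > 26000 nM in this assay, at which 3 of the 3 values shown sit. The compounds shown leave open whether furan-2-yl and pyridin-4-yl differ at all in this read-out, and at what concentration any of the three would show an effect.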